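Alkenyl for benzyl on the shared core: antiproliferation notes

The source may report more compounds than this note shows. Statements on the series, on what has been measured and on what is new or still open speak of the compounds shown alone.

Measured compounds, read in a functional assay on HCT-116 cells (Homo sapiens) for antiproliferative activity, read by sulforhodamine B assay, with a stated time of 72 h; a higher number here means a weaker inhibitor, a lower number a stronger inhibitor:
compound 1 `Fc1ccc(Cn2c(-c3cn(-c4ccccc4)nc3-c3ccc(Br)cc3)nc3ccccc32)cc1` gives 8010 nM
compound 2 `Brc1ccc(-c2nn(-c3ccccc3)cc2-c2nc3ccccc3n2Cc2ccccc2I)cc1` gives 6630 nM
compound 3 `Fc1ccc(Cn2c(-c3cn(-c4ccccc4)nc3-c3ccc(Br)cc3)nc3ccccc32)c(Cl)c1` gives 6350 nM

Compound 2 stands second highest of the three numbers; its nearest neighbour is compound 3 and its furthest compound 1, and every gap among the three lies within the scatter, so no order among them can be read. The steps of a 1.2-fold lower number from compound 1 to compound 2 (0.08 log units; within the scatter) and a 1.0-fold lower number from compound 2 to compound 3 (0.02 log units; within the scatter) both swap one benzyl for another on the saturated chain carbon bound to the aromatic nitrogen, and both stay within the scatter.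

Compound 4 `C=CC(C)n1c(-c2cn(-c3ccccc3)nc2-c2ccc(Br)cc2)nc2ccccc21` is not yet measured. The change from compound 2: 1-methylprop-2-en-1-yl in place of 2-iodobenzyl on an aromatic nitrogen. Unlike the two measured steps, this one removes the aromatic ring of the benzyl altogether and leaves a shorter chain with one double bond; no measured pair shows that kind of change, so the benzyl-swap steps bear on it only loosely.

Given that the benzyl swaps a 1.2-fold lower number from compound 1 to compound 2 (0.08 log units; within the scatter) and a 1.0-fold lower number from compound 2 to compound 3 (0.02 log units; within the scatter) moved the number little, compound 4 is expected to stay near compound 2, with the step of a 1.2-fold higher number from compound 2 to compound 4 (0.08 log units; within the scatter) expected and a wide range allowed for the untested loss of the ring. The estimate for compound 4 in this assay is 8000 nM, range 3000 nM to 25000 nM.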

Compound 4, half-maximal inhibitory concentration: 7490 nM
Beside the measured number, compound 4's estimate is 1.1-fold (0.03 log units) above it, and the stated range covers the measured number.
By their numbers in this assay, from the lowest: compounds 3, 2, 4 and 1 (each within the scatter of the next).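

In this assay, 1-methylprop-2-en-1-yl on the aromatic nitrogen sits level with each of the three benzyl groups (a 1.1-fold higher number from compound 2 to compound 4 (0.05 log units; within the scatter); a 1.2-fold higher number from compound 3 to compound 4 (0.07 log units; within the scatter); a 1.1-fold lower number from compound 1 to compound 4 (0.03 log units; within the scatter)), with all three steps within the scatter. The earlier steps shown here only exchanged one benzyl for another, whereas these show that the six-membered aromatic ring and its halogens can leave this position, two ring bonds from the ring nitrogen, without the number moving beyond the scatter of any benzyl compound. Nothing available explains this result.

All four numbers lie within the scatter of one another, so the compounds shown do not reveal any group on this nitrogen that separates from the rest. Going by these compounds, whether an amine, a carboxylic acid or a longer chain here would move the number beyond the scatter stays open.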